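A few compounds are considered here, and "the series" means these few. Any claim that something is new, unique, unknown or untested is made for them only; others in the source may bear on it.

Measured compounds:
- compound 1 `Nc1cc(N)c2nc(-c3ccccc3)c(Oc3ccc(Cl)c(Cl)c3)nc2c1` — < 100000 nM
- compound 2 `COc1ccc(Sc2nc3cc(N)cc(N)c3nc2-c2ccccc2)cc1` — < 100000 nM

In a functional assay on UO-31 cells (Homo sapiens) for inhibition, read by sulforhodamine B assay, with a stated time of 48 h (a higher number here means a weaker inhibitor of growth, a lower number a stronger inhibitor of growth), compound 1 gives < 100000 nM, which is a limit of the assay rather than a number. Compound 2 gives < 100000 nM in this assay, again only a limit. The step that the two limits leave unreadable from compound 1 to compound 2 therefore cannot be sized, and compound 2 stands at the limit, as the limit of < 100000 nM in this assay, at which 2 of the 2 values shown sit, records.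

Compound 3 `Nc1cc(N)c2nc(-c3ccccc3)c(Sc3ccc(Cl)c(Cl)c3)nc2c1` differs from compound 2 by 3,4-dichlorophenyl in place of 4-methoxyphenyl on a sulfur. Among the compounds with values here, the single measured step, from compound 1 to compound 2, changes both the bridging atom and the aryl group at once and is unreadable, so no measured step isolates the aryl change on a sulfur. Compound 3 carries the 3,4-dichlorophenyl of compound 1 together with the sulfur of compound 2. Compound 3 is consequently expected to remain at or near the limit, with a step that the limit leaves unreadable from compound 2 to compound 3 estimated as no step beyond the scatter. The estimate for compound 3 is 30000 nM, range 3000 nM to 100000 nM, most probably reported again as a limit.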

Compound 3, concentration for total growth inhibition: < 100000 nM
Compound 3: only a limit was reported; the forecaster's own chance of this, stated with the estimate: 60%; the middle value does not contradict the limit.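

Compound 3 gives < 100000 nM in this assay, which is a limit and not a number. Compound 1 and compound 2 are also limits, so no step among the three compounds can be read: the limit of < 100000 nM in this assay, at which 3 of the 3 values shown sit.

The compounds shown leave open whether exchanging the aryl group or the bridging atom changes growth inhibition at all.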